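The source may report more compounds than this note shows. Statements on the series, on what has been measured and on what is new or still open speak of the compounds shown alone.

Of the compounds shown here, three with a shared core have been measured in an ADME assay on isolated protein for inhibition of Amine oxidase [flavin-containing] A (Homo sapiens), read by fluorescence and Amplex Red, with stated times of 15 min and 20 min; on this read-out lower numbers stand for stronger inhibition and higher numbers for weaker inhibition. Among the measured compounds shown here, compound 1 `C#CCN(CCCCOc1ccc2ccc(=O)oc2c1)Cc1ccc(OC)cc1` gives 54500 nM, and compound 2 `C#CCN(CCCCOc1ccc2ccc(=O)oc2c1)Cc1cccc(F)c1` gives 69200 nM; the one step between them, a 1.3-fold higher number from compound 1 to compound 2 (0.10 log units; within the scatter), is small. Compound 3 `C#CCN(C)CCCOc1ccc2ccc(=O)oc2c1` gives 36900 nM, the lowest of the three numbers, though both others sit within the scatter of it, so no order among the three can be claimed.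

Compound 4 `C#CCN(CCCOc1ccc2ccc(=O)oc2c1)Cc1ccc(C(C)C)cc1` is reached from compound 3 by one change: 4-isopropylphenyl in place of hydrogen on a saturated chain carbon bound to an amine nitrogen. For the measured compounds named here, none of the measured steps covers this change. Going by the values given here, the only step on record, a 1.3-fold higher number from compound 1 to compound 2 (0.10 log units; within the scatter), swaps one ring for another on the same chain carbon and stays within the scatter; it says nothing about adding a ring where a hydrogen was. Compounds 1 and 2 carry a ring on that carbon and give numbers within the scatter of compound 3, but they also differ from compound 3 elsewhere, so they offer no clean comparison.

On this basis the expected step of a 1.1-fold higher number from compound 3 to compound 4 (0.04 log units; within the scatter) in this assay is none beyond the scatter. Compound 4 is therefore estimated at 40000 nM in this assay, within a range from 10000 nM to 160000 nM, the width reflecting the lack of a direct precedent.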

Compound 4, half-maximal inhibitory concentration: 77400 nM
Estimate against measurement, compound 4: 1.9-fold (0.29 log units) below; the range from low to high includes it.
By their numbers in this assay, from the lowest: compounds 3, 1, 2 and 4 (each within the scatter of the next, the first and the last beyond it).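

In this assay, among the compounds shown here, a 4-isopropylphenyl group in place of hydrogen on a saturated chain carbon bound to an amine nitrogen gives a 2.1-fold higher number from compound 3 to compound 4 (0.32 log units; beyond the scatter) and is the first step in this set to lie beyond the usual scatter, though only modestly. This position therefore responds to what it carries, and here the added ring goes with weaker inhibition, a one-place comparison that compounds 1 and 2 could not give, as they also differ from compound 3 elsewhere. Nothing measured here accounts for why the number rises with this change.

From the compounds shown here alone, it remains open whether a smaller group at this position, such as a methyl or an unsubstituted phenyl, would move the number in the same way, or whether the isopropyl on the ring matters to the step. Going by these compounds, it is also open whether a carboxylic acid or an amine on that ring in place of the isopropyl would keep the weaker inhibition, and whether the same change would have a similar effect on a longer chain.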